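Hydrogen for methyl on an aromatic nitrogen: expected tolerance

This account rests on a few compounds, and the source may have more. Where it says the series, first, only, none or still open, it means among the compounds named here.

Compound 1 `CC(=O)Nc1ccc(-c2nc3cc(C(F)(F)F)ccc3n2C)cc1`: in an ADME assay on Vero cells (Chlorocebus sabaeus) for cytotoxicity (a higher number here means that more compound is tolerated, a lower number that less compound is tolerated), compound 1 gives > 100000 nM, which is a limit of the assay.
Compound 2 `Cn1c(-c2ccc(NC(=O)CN3CCN(c4ccccc4)CC3)cc2)nc2cc(C(F)(F)F)ccc21`: in this assay compound 2 gives 30000 nM.
Compound 3 `Cn1c(-c2ccc(NC(=O)CN3CCCCC3)cc2)nc2cc(C(F)(F)F)ccc21`: in this assay compound 3 gives > 100000 nM, which is a limit of the assay.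

Compound 2 thus stands as the only numerical result among the three; compound 1 and compound 3 each sit at a limit, as the limit of > 100000 nM in this assay, at which 2 of the 3 values shown sit, records. The new compound 4 `O=C(CN1CCN(c2ccccc2)CC1)Nc1ccc(-c2nc3cc(C(F)(F)F)ccc3[nH]2)cc1` differs from compound 2 by hydrogen in place of methyl on an aromatic nitrogen.

The measured steps all alter the group on the saturated chain carbon bound to the carbonyl carbon, not the aromatic nitrogen. They were an at least 3.3-fold lower number from compound 1 to compound 2 (0.52 log units; beyond the scatter), an at least 3.3-fold higher number from compound 2 to compound 3 (0.52 log units; beyond the scatter), and a step that the two limits leave unreadable from compound 1 to compound 3. None of them touches the position changed in compound 4, so none bears directly on this step, and for the step from compound 2 to compound 4 no change beyond the scatter in this assay is expected. Compound 4 is therefore estimated to give 30000 nM, with a range from 10000 nM to 100000 nM. That estimate means an expected step of no change at the digits printed from compound 2 to compound 4 (within the scatter).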

Compound 4, half-maximal cytotoxic concentration: > 100000 nM
Compound 4 gave a limit, no number; the forecaster's own chance of this, stated with the estimate: 30%; middle value at least 3.3-fold (0.52 log units) from the limit.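

In this assay, the aromatic nitrogen of the five-membered ring proves to be a position that matters: hydrogen in place of methyl there gives an at least 3.3-fold higher number from compound 2 to compound 4 (0.52 log units; beyond the scatter). Going by these compounds alone, the 4-phenylpiperazin-1-yl group stays in place across this step, so the lower number of compound 2 depends on the methyl as well as on that group, a link between two places that the earlier steps, all made on the saturated chain carbon, could not show. Compound 4 gives > 100000 nM, which is a limit of the assay, and it joins the other compounds that sit there: the limit of > 100000 nM in this assay, at which 3 of the 4 values shown sit.

The compounds shown leave open whether an ethyl group or a longer chain on this nitrogen would behave like the methyl of compound 2 or like the hydrogen of compound 4. Within the data shown here, with compound 2 as the only compound giving a number, they also leave open how far the number rises with hydrogen on this nitrogen, and whether a phenyl ring bearing a fluorine or a methoxy group on the piperazine would keep the link to the methyl.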